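This account rests on a few compounds, and the source may have more. Where it says the series, first, only, none or still open, it means among the compounds named here.

Measured so far:
compound 1 `O=C1O[C@H]([C@@H](O)Cn2cc(-c3cccc(O)c3)nn2)C(OCc2ccccc2)=C1OCc1ccccc1`: 42900 nM
compound 2 `COc1ccccc1-c1cn(C[C@H](O)[C@H]2OC(=O)C(OCc3ccccc3)=C2OCc2ccccc2)nn1`: > 100000 nM
compound 3 `COc1ccccc1-c1cn(C/C=C2\OC(=O)C(OCc3ccccc3)=C2OCc2ccccc2)nn1`: > 100000 nM

In a functional assay on HCT-116 cells (Homo sapiens) for antiproliferative activity, read by MTT assay, with a stated time of 72 h (on this read-out higher numbers stand for weaker inhibition and lower numbers for stronger inhibition), compound 1 gives 42900 nM. For compound 2 this assay reports only a limit, > 100000 nM. For compound 3 this assay likewise reports only a limit, > 100000 nM. Compound 1 and compound 2 share a core and differ in one place: 3-hydroxyphenyl in place of 2-methoxyphenyl on an aromatic carbon. This change brought an at least 2.3-fold lower number from compound 2 to compound 1 (0.36 log units; beyond the scatter), though the starting point is only (the limit of > 100000 nM in this assay, at which 2 of the 3 values shown sit), so the true size of that step is not pinned down.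

Compound 3 carries a different core, and the difference between the two cores is not broken down here. Compound 4 `O=C1O/C(=C\Cn2cc(-c3cccc(O)c3)nn2)C(OCc2ccccc2)=C1OCc1ccccc1` is not yet measured; it arises from compound 3 by the same change, (3-hydroxyphenyl in place of 2-methoxyphenyl on an aromatic carbon). Because the step of an at least 2.3-fold lower number from compound 2 to compound 1 (0.36 log units; beyond the scatter) went toward a stronger value, the same change on compound 3 is expected to give a similar step, an at least 1.5-fold lower number from compound 3 to compound 4 (0.18 log units; that floor lies within the scatter). Since compound 3 sits at a limit, the estimate stays uncertain, and compound 4 is expected to land near 65000 nM, within roughly 20000 nM to 200000 nM.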

Compound 4, half-maximal inhibitory concentration: 63600 nM
Estimate against measurement, compound 4: 1.0-fold (0.01 log units) above; the range from low to high includes it.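

In this assay, the same change on the second core gave an at least 1.5-fold lower number from compound 3 to compound 4 (0.19 log units; that floor lies within the scatter). This agrees in direction with the earlier step, so 3-hydroxyphenyl in place of 2-methoxyphenyl goes with a lower number on both cores shown, although the floor of the new step lies within the usual scatter, and two pairs are too few to make this a general rule. It does not show that the change has the same size on each core: the same change on two cores in this assay, an at least 2.3-fold lower number (0.36 log units; beyond the scatter) from compound 2 to compound 1 and an at least 1.5-fold lower number (0.19 log units; that floor lies within the scatter) from compound 3 to compound 4; the limit leaves it open whether they differ.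

The compounds shown leave open whether the step comes from adding the hydroxyl group or from losing the methoxy group, as both happen in one change. They also leave open how a plain phenyl group, or a phenyl ring carrying an amine or a carboxylic acid instead of the hydroxyl group, would behave on either core.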